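Notes on two measured compounds and one untested analogue

The source may report more compounds than this note shows. Statements on the series, on what has been measured and on what is new or still open speak of the compounds shown alone.

Measured so far:
compound 1 `O=C(C=CNc1cc(-c2ccccc2)nn1-c1ccccc1)c1cccs1` — 2420 nM
compound 2 `N#Cc1c(-c2ccc(Cl)cc2)nc2c(c(-c3ccccc3)nn2-c2ccccc2)c1-c1ccc(N2CCCCC2)cc1` — 3210 nM

Both numbers come from a functional assay on HepG2 cells (Homo sapiens) for inhibition, read by MTT assay, with a stated time of 48 h; a higher number here means a weaker inhibitor, a lower number a stronger inhibitor. Compound 1 gives the smaller number of the two, yet its gap to compound 2 lies within the usual scatter, so no order between them is claimed. Among the measured compounds shown here, the two share no single-point relationship, and no step between measured compounds is available.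

Compound 3 `O=C(C=CNc1cc(-c2ccccc2)nn1-c1ccccc1)c1ccccc1` has not been measured. It differs from compound 1 by phenyl in place of thiophen-2-yl on a carbonyl carbon. For the measured compounds named here, there is no measured pair in this set that isolates such an exchange, so the expectation rests on compound 1 alone.

The step from compound 1 to compound 3 is expected to be a 1.2-fold higher number from compound 1 to compound 3 (0.08 log units; within the scatter), that is, no shift beyond the scatter in either direction. Compound 3 is therefore estimated at 2900 nM in this assay, with a likely range from 1200 nM to 7500 nM.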

Compound 3, half-maximal inhibitory concentration: 2660 nM
Beside the measured number, compound 3's estimate is 1.1-fold (0.04 log units) above it; measured number inside the range.
By their numbers in this assay, from the lowest: compounds 1, 3 and 2 (each within the scatter of the next).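

In this assay, among the compounds shown here, the only single-point step available is a 1.1-fold higher number from compound 1 to compound 3 (0.04 log units; within the scatter), with phenyl in place of thiophen-2-yl on a carbonyl carbon. At this place, the five-membered aromatic ring with its sulfur and the six-membered aromatic ring of carbon only are therefore not told apart by this read-out, so the sulfur atom is not needed for a value of this size in this pair. Nothing at hand explains this outcome.

Going by these compounds, whether this tolerance extends beyond aromatic rings stays open: an amine, a carboxylic acid or a short alkyl chain on the same carbonyl carbon could give a different picture. Compound 2 remains unconnected to this pair by any single-point step, so how its groups contribute cannot be read.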